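This account rests on a few compounds, and the source may have more. Where it says the series, first, only, none or still open, it means among the compounds named here.

Working notes on the series. In a functional assay on HT-29 cells (Homo sapiens) for antiproliferative activity, read by MTT assay, with a stated time of 24 h (a higher number here means a weaker inhibitor, a lower number a stronger inhibitor), compound 1 (`COc1ccc(C(=O)/C=C/c2cc(OC)c(OC)c(OC)c2)c2c1C=CC(C)(C)O2`) gives > 10000 nM, which is a limit and not a number. Compound 2 (`COc1cc(OC)c(OC)cc1/C=C/C(=O)c1ccc(OC)c2c1OC(C)(C)C=C2`) gives > 10000 nM, again a limit. Compound 3 (`COc1ccc(C(=O)/C=C/c2ccc(F)cc2)c2c1C=CC(C)(C)O2`) gives > 10000 nM, also a limit. Among the compounds with values here, the series so far shows only (the limit of > 10000 nM in this assay, at which 3 of the 3 values shown sit), so compound 3 has a limit and no number, and no measured step is available. Compound 4 (`COc1ccc(C(=O)/C=C/c2ccc(N(C)C)cc2)c2c1C=CC(C)(C)O2`) carries dimethylamino in place of fluoro on an aromatic carbon, para to a large group: dimethylamino in place of fluoro on an aromatic carbon. In this assay, little change is expected, with at most a modest gain in potency, and the reading may again stop at a limit. The expected size of the change is a number no higher from compound 3 to compound 4 (the limit leaves the size open). For compound 4 the estimated value is 10000 nM, with an expected range of 3000 nM to 30000 nM.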

Compound 4, half-maximal inhibitory concentration: 1870 nM
Compound 4: middle estimate off by 5.3-fold (0.73 log units), on the high side; measured number outside the range, below it.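

Within the data shown here, compound 4 is the first compound to give a number rather than a limit in this assay, which shows that this aromatic carbon, para to a large group, is sensitive to the group it carries. Dimethylamino in place of fluoro gives an at least 5.3-fold lower number from compound 3 to compound 4 (0.72 log units; beyond the scatter). The true size of that step stays unknown, as compound 3 has a limit and not a number, and the limit is still the most common reading in the series: the limit of > 10000 nM in this assay, at which 3 of the 4 values shown sit.

From the compounds shown here alone, whether a primary amine or a methoxy at this position would read like dimethylamino remains open. So does whether the gain depends on dimethylamino itself or would appear with a larger amine such as morpholine.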